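Series notes: the ring chloro of compound 1

The source may report more compounds than this note shows. Statements on the series, on what has been measured and on what is new or still open speak of the compounds shown alone.

Compound 1 `Clc1cncc(N2CCCNCCC2)c1` is tested in a functional assay on HEK293 cells for agonist activity at Neuronal acetylcholine receptor; alpha4/beta2 (Homo sapiens), read by FLIPR and calcium flux (on this read-out higher numbers stand for an effect only at larger amounts of compound and lower numbers for an effect already at smaller amounts), where compound 1 gives 170 nM. Among the three measured compounds this is the second highest number. Compound 3 `Oc1cncc(N2CCCNCC2)c1` gives 141 nM in this assay, which lies within the scatter of compound 1. Compound 2 `COc1cncc(N2CCCNCC2)c1` gives 1410 nM, beyond the scatter of compound 1. Among the measured compounds shown here, the only measured one-place step is a 10-fold lower number from compound 2 to compound 3 (1.00 log units; beyond the scatter), a change on an oxygen on an aromatic ring.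

Compound 4 `c1cncc(N2CCCNCCC2)c1` differs from compound 1 by hydrogen in place of chloro on an aromatic carbon. For the measured compounds named here, no measured pair shows this same change; the step from compound 2 to compound 3 concerns a different group and offers no direct guide, so the shared core and the number for compound 1 are the only anchors. The chloro group leaves with nothing in its place, and the expected step is a 2.9-fold higher number from compound 1 to compound 4 (0.47 log units; beyond the scatter), toward a higher number, carrying wide uncertainty. Compound 4 is estimated at 500 nM in this assay, with a range from 150 nM to 1700 nM.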

Compound 4, half-maximal effective concentration: 36.3 nM
Compound 4: middle estimate off by 14-fold (1.14 log units), on the high side; the measured number lies below the stated range.
By their numbers in this assay, from the lowest: compound 4; then compounds 3 and 1 (each within the scatter of the next); then compound 2.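

On the aromatic carbon two atoms from the ring nitrogen, hydrogen in place of chloro gives a 4.7-fold lower number from compound 1 to compound 4 (0.67 log units; beyond the scatter) in this assay, so on the core of compound 1 the chloro group is not required for a low number. Among the compounds shown here, this is the first measured step at this carbon; the earlier step, a 10-fold lower number from compound 2 to compound 3 (1.00 log units; beyond the scatter), concerned a change on an oxygen on an aromatic ring and gave no reading of the chloro group. Nothing available here accounts for the size or direction of the new step.

Going by these compounds, whether other groups on this carbon, such as fluoro, methyl or an amine, would also give a number above that of hydrogen remains open. Also open, on these data alone, is whether hydrogen in place of chloro gives a step of similar size on the core of compound 3, which differs from the core of compound 1.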